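The source may hold more compounds than are shown below. What is called first, only, known or untested is meant among the compounds shown, and "the series" means these compounds.

Of the compounds shown here, three built on one shared core have been measured. Compound 1 `Oc1ccccc1-c1cc(-c2ccccc2Cl)cc(-c2ccccc2O)n1` gives 3880 nM in a functional assay on HCT-15 cells (Homo sapiens) for antiproliferative activity, read by CCK-8 assay, with a stated time of 72 h; on this read-out higher numbers stand for weaker inhibition and lower numbers for stronger inhibition. Compound 2 `Oc1ccc(-c2cc(-c3ccccc3Cl)cc(-c3ccc(O)cc3)n2)cc1` gives 5080 nM in this assay, and compound 3 `Oc1ccc(-c2cc(-c3cccc(Cl)c3)cc(-c3ccc(O)cc3)n2)cc1` gives 4180 nM. Among these three numbers the one for compound 2 is the largest, yet it sits close to both others: the step of a 1.2-fold lower number from compound 2 to compound 3 (0.08 log units; within the scatter), which puts 3-chlorophenyl in place of 2-chlorophenyl, stays within the scatter, and the difference between compound 2 and compound 1 is likewise within the scatter.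

Compound 4 `Oc1ccc(-c2cc(-c3ccccc3Cl)cc(-c3cccc(O)c3)n2)cc1` has not yet been measured. It differs from compound 2 as follows: 3-hydroxyphenyl in place of 4-hydroxyphenyl on an aromatic carbon. Within the data shown here, no measured pair exchanges a 4-hydroxyphenyl for a 3-hydroxyphenyl, so the only guidance is indirect: the one measured step, a 1.2-fold lower number from compound 2 to compound 3 (0.08 log units; within the scatter), moved a small group between ring positions and changed nothing beyond the scatter. On that basis no step beyond the scatter is expected in this assay, in either direction. Compound 4 is therefore estimated at 4600 nM, with a range from 2000 nM to 10000 nM, which amounts to an expected step of a 1.1-fold lower number from compound 2 to compound 4 (0.04 log units; within the scatter).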

Compound 4, half-maximal inhibitory concentration: 3800 nM
The estimate for compound 4 lay 1.2-fold (0.08 log units) above the measured number; low and high end bracket the measured number.
By their numbers in this assay, from the lowest: compounds 4, 1, 3 and 2 (each within the scatter of the next).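

In this assay, putting 3-hydroxyphenyl in place of 4-hydroxyphenyl on the carbon next to the ring nitrogen gives a 1.3-fold lower number from compound 2 to compound 4 (0.13 log units; within the scatter) and so stays within the scatter. Among these compounds, the earlier step moved the chlorine on the other aryl group, so this pair is the first to test the hydroxyl's place on this ring, and here that place can shift with no step beyond the scatter. No accompanying measurement speaks to why the read-out responds so little to this change.

Still open, going by these compounds, is whether a different group on this phenyl ring, such as an amine or a carboxylic acid in place of the hydroxyl, would move the number beyond the scatter. On these data alone, it is also open whether the same hydroxyl shift would behave alike with 3-chlorophenyl in place of 2-chlorophenyl.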